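A few compounds are considered here, and "the series" means these few. Any claim that something is new, unique, unknown or untested is made for them only; others in the source may bear on it.

Of the compounds shown here, three share one core and have been tested in a functional assay on the whole organism with Rattus norvegicus as the target; on this read-out higher numbers stand for an effect only at larger amounts of compound and lower numbers for an effect already at smaller amounts. Compound 1, `CCCCCCCc1ccc2nc(N)sc2c1`, is one of them. In this assay compound 1 reaches only the limit of > 10 mg/kg, which is a limit of the method and not a number. Compound 2, `Nc1nc2ccc(C(F)(F)C(F)(F)F)cc2s1`, is the only one of the three with a real number: in this assay compound 2 gives 2.5 mg/kg. Compound 3, `N=c1sc2cc(OC(F)(F)F)ccc2n1CC(=O)O`, carries a carboxymethyl group on its aromatic nitrogen. In this assay compound 3 also stops at > 10 mg/kg, again a limit rather than a number. So compound 3 stands where compound 1 stands, at the limit of > 10 mg/kg in this assay, at which 2 of the 3 values shown sit.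

The new compound 4, `CCSCCn1c(=N)sc2cc(OC(F)(F)F)ccc21`, differs from compound 3 in a single place: (ethylsulfanyl)methyl in place of carboxy on a saturated chain carbon bound to an aromatic nitrogen. Nothing in the three measured compounds shows the size of such a change, and the limit of compound 3 leaves the starting point open. The expectation is still that compound 4 moves toward smaller doses in this assay, with a step of an at least 2.0-fold lower number from compound 3 to compound 4 (0.30 log units; that floor lies within the scatter). For compound 4 the estimated dose in this assay is 5 mg/kg, with a range from 2 mg/kg to 20 mg/kg, and a real chance that only a limit is reported.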

Compound 4, dose for half-maximal effect: 2.2 mg/kg
Compound 4: the middle estimate sits 2.3-fold (0.36 log units) above what was measured; low and high end bracket the measured number.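

The place on the chain bound to the aromatic nitrogen turns out to tolerate a change that brings a real number into view: in this assay compound 4 gives 2.2 mg/kg. Among the compounds shown here, replacing carboxymethyl with 2-(ethylsulfanyl)ethyl produces an at least 4.5-fold lower number from compound 3 to compound 4 (0.65 log units; beyond the scatter), which is the first step in this set that can be read at all, and it shows that the group on this nitrogen can matter for the dose needed in the whole animal. This step is only a floor and its full size stays unknown, because compound 3 sits at a limit of the assay and not at a number: the limit of > 10 mg/kg in this assay, at which 2 of the 4 values shown sit.

This single pair cannot separate the loss of the carboxy group from the arrival of the sulfur-bearing chain, so it remains open which of the two accounts for the step. From the compounds shown here alone, a plain pentyl chain, a chain with an ether oxygen in place of the sulfur, or the ethyl ester of the acid at this place would be needed to tell these apart, and whether the step holds on other cores remains open as well.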